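The source may report more compounds than this note shows. Statements on the series, on what has been measured and on what is new or still open speak of the compounds shown alone.

Measured in a functional assay on KB cells (Homo sapiens) for cytotoxicity; a lower number here means a stronger inhibitor, a higher number a weaker inhibitor:
- Compound 1 `COC(=O)c1ccc(C(=O)Nc2cccc3c2N(S(=O)(=O)c2ccc(OC)cc2)CC3)cc1`: 376 nM
- Compound 2 `COc1ccc(S(=O)(=O)N2CCc3cc(Br)cc(NC(=O)c4ccco4)c32)cc1`: 89 nM

Of these two, compound 2 has the lower number, and its gap to compound 1 lies beyond the usual scatter. The two compounds differ in more than one place, so this gap does not isolate the bromo group.

Compound 3 `COc1ccc(S(=O)(=O)N2CCc3cccc(NC(=O)c4ccco4)c32)cc1` has not yet been measured. It is compound 2 with hydrogen in place of bromo on an aromatic carbon. Among the measured compounds shown here, no measured pair shows this change alone, so any forecast for it is loose. A modest move toward a lower number is expected, although a move the other way cannot be ruled out. The estimated change is a 2.2-fold lower number from compound 2 to compound 3 (0.35 log units; beyond the scatter). Compound 3 is expected at about 40 nM, with an estimated range of 12 nM to 160 nM.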

Compound 3, half-maximal inhibitory concentration: 9.6 nM
Beside the measured number, compound 3's estimate is 4.2-fold (0.62 log units) above it; the measured number lies below the stated range.
By their numbers in this assay, from the lowest: compound 3; then compound 2; then compound 1.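

In this assay, among the compounds shown here, the swap of bromo for hydrogen gives a 9.3-fold lower number from compound 2 to compound 3 (0.97 log units; beyond the scatter) and so shows, for the first time in a single-change pair, that bromo on this aromatic carbon, para to a fused ring, costs activity. The gap seen earlier between compound 1 and compound 2 mixed two changes, but furan-2-yl in place of 4-(methoxycarbonyl)phenyl on the carbonyl carbon can now be read alone, as a 39-fold lower number from compound 1 to compound 3 (1.59 log units; beyond the scatter) and so this group matters too. Nothing available explains either step.

Each change rests on a single pair, so neither can be called a general pattern. As far as these compounds go, whether a methyl group, a chlorine atom or an amine on this carbon would sit closer to hydrogen or to bromo stays open.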